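The source may report more compounds than this note shows. Statements on the series, on what has been measured and on what is new or still open speak of the compounds shown alone.

Measured in a functional assay on MDA-MB-231 cells (Homo sapiens) for antiproliferative activity, read by MTT assay, with a stated time of 72 h; a lower number here means a stronger inhibitor, a higher number a weaker inhibitor:
- Compound 1 `O=c1oc2cc(O)ccc2cc1-c1ccc(O)c(F)c1`: > 100000 nM, a limit
- Compound 2 `Cc1cc(O)ccc1-c1c(C)c2ccc(O)cc2oc1=O`: > 100000 nM, a limit
- Compound 3 `CCc1c(-c2ccc(O)c(F)c2)c(=O)oc2cc(O)ccc12`: 48600 nM

Compound 3 is the only one of the three with an actual number. Compound 4 `O=c1oc2cc(O)ccc2c(-c2ccc(O)c(F)c2)c1-c1ccc(O)c(F)c1` carries a 3-fluoro-4-hydroxyphenyl in place of the ethyl of compound 3, on the aromatic carbon opposite the ring oxygen: 3-fluoro-4-hydroxyphenyl in place of ethyl on an aromatic carbon. Among the measured compounds shown here, the one measured step at this carbon is an at least 2.0-fold lower number from compound 1 to compound 3 (0.31 log units; beyond the scatter). Compound 2 also carries a methyl on that carbon, yet its > 100000 nM is a limit. The evidence is thin, and only a modest further fall in this assay is expected, an estimated 2.4-fold lower number from compound 3 to compound 4 (0.39 log units; beyond the scatter). For compound 4 the estimated value is 20000 nM, with an expected range of 4000 nM to 100000 nM.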

Compound 4, half-maximal inhibitory concentration: > 100000 nM
Compound 4 gave a limit, no number; the forecaster's own chance of this, stated with the estimate: 25%; middle value at least 5.0-fold (0.69 log units) from the limit.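

Replacing ethyl with the larger 3-fluoro-4-hydroxyphenyl on the carbon opposite the ring oxygen does not extend the gain seen with ethyl: in this assay there is an at least 2.0-fold higher number from compound 3 to compound 4 (0.31 log units; beyond the scatter). At this carbon, then, a measurable value is kept with ethyl and lost with the aromatic ring. The step between the two compounds that both end in limits, compound 1 and compound 4, cannot be read.

As far as these compounds go, whether a propyl chain or an amine on this carbon would lower the number stays open. Most of the comparisons remain limited: the limit of > 100000 nM in this assay, at which 3 of the 4 values shown sit.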